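The source may report more compounds than this note shows. Statements on the series, on what has been measured and on what is new or still open speak of the compounds shown alone.

Compound 1 `Cc1ccccc1NC(=O)NCC1(c2ccccc2)CCCCC1` is the reference point of this small urea series. In an assay on microsomes from intestine for inhibition of acyl-CoA:cholesterol acyltransferase (Oryctolagus cuniculus) (a higher number here means a weaker inhibitor, a lower number a stronger inhibitor), compound 1 gives 640 nM, the lowest number of the three measured; compound 2 `O=C(NCC1(c2ccccc2)CCCCC1)Nc1cccc(Cl)c1Cl` gives 1300 nM and compound 3 `O=C(NCC1(c2ccccc2)CCCCC1)Nc1cc(Cl)ccc1Cl` gives 2700 nM. The steps that swap the aryl substitution pattern all raise the number: a 2.0-fold higher number from compound 1 to compound 2 (0.31 log units; beyond the scatter), a 4.2-fold higher number from compound 1 to compound 3 (0.63 log units; beyond the scatter), and a 2.1-fold higher number from compound 2 to compound 3 (0.32 log units; beyond the scatter).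

Compound 4 `Cc1cccc(C(C)(C)C)c1NC(=O)NCC1(c2ccccc2)CCCCC1` differs from compound 1 by tert-butyl in place of hydrogen on an aromatic carbon. Going by the values given here, none of the measured steps adds a group to the ring of compound 1; they only exchange one ring pattern for another, each at modest cost. On that basis compound 4 is expected to stay near compound 1, with the step of a 1.4-fold lower number from compound 1 to compound 4 (0.15 log units; within the scatter) not beyond the scatter and carrying wide uncertainty. The estimate for compound 4 is 450 nM, in the range 130 nM to 1500 nM.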

Compound 4, half-maximal inhibitory concentration: 54 nM
The estimate for compound 4 lay 8.3-fold (0.92 log units) above the measured number; measured number outside the range, below it.
By their numbers in this assay, from the lowest: compound 4; then compound 1; then compound 2; then compound 3.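

Adding tert-butyl in place of hydrogen, ortho to a large group and meta to a methyl group, gives a 12-fold lower number from compound 1 to compound 4 (1.07 log units; beyond the scatter), a large step. The earlier steps shown here only exchanged one ring pattern for another and each raised the number, whereas this added group lowers it, so this ring position accepts tert-butyl without loss in this assay. No evidence here accounts for the gain.

On these data alone, whether isopropyl, a methoxy group or a carboxylic acid at this position would give a similar step remains open. So does whether tert-butyl would lower the number on the ring of compound 2.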